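Ethoxy to Methoxy: What Compound 4 Might Give

This account rests on a few compounds, and the source may have more. Where it says the series, first, only, none or still open, it means among the compounds named here.

Three compounds have been measured in a functional assay on A-375 cells (Homo sapiens) for antiproliferative activity, read by MTT assay, with a stated time of 24 h, tested at 33.33 ug/mL; on this read-out higher numbers stand for a stronger effect at the one concentration tested and lower numbers for a weaker effect:

Compound 1, `Cc1ccc2nc(C(=O)Nc3c(F)cc(-c4cccc(F)c4)cc3F)c(C)c(O)c2c1`, gives 26.5%.
Compound 2, `CCc1ccc2nc(C(=O)Nc3c(F)cc(-c4cccc(F)c4)cc3F)c(C)c(O)c2c1`, gives 28.4%.
Compound 3, `CCOc1ccc2nc(C(=O)Nc3c(F)cc(-c4cccc(F)c4)cc3F)c(C)c(C(=O)O)c2c1`, gives 51.2%.

Compound 1 and compound 2 share one core and differ only by hydrogen in place of methyl on a saturated chain carbon bound to an aromatic carbon. This change leaves the read-out essentially unmoved, a number 1.9 percentage points lower from compound 2 to compound 1 (within the scatter). Compound 3 stands on a different core, and the difference between the two cores is not broken down here; its value is beyond the scatter above both compound 1 and compound 2.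

Compound 4, `COc1ccc2nc(C(=O)Nc3c(F)cc(-c4cccc(F)c4)cc3F)c(C)c(C(=O)O)c2c1`, is not yet measured. It arises from compound 3 by hydrogen in place of methyl on a saturated chain carbon bound to an oxygen on an aromatic ring. The change from compound 2 to compound 1 is the same kind of change, but not the same: there the methyl left a saturated chain carbon bound to an aromatic carbon, whereas here it leaves a saturated chain carbon bound to an oxygen on an aromatic ring.

Among the measured compounds shown here, on the only evidence available, the near-zero step a number 1.9 percentage points lower from compound 2 to compound 1 (within the scatter), the expectation is a small step in this assay from compound 3 to compound 4, estimated as a number 3.2 percentage points lower from compound 3 to compound 4 (within the scatter). Compound 4 is therefore expected to give about 48% in this assay, with a plausible range from 35% to 60%; the different surroundings of the change widen this range.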

Compound 4, a percentage reported as inhibition, at one concentration (the size of the read-out at that concentration, not a potency): 44.5%
Compound 4: the middle estimate sits 3.5 percentage points above what was measured; the measured number falls inside the stated range.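

In this assay the ethoxy to methoxy change on the core of compound 3 reads as a number 6.7 percentage points lower from compound 3 to compound 4 (within the scatter), so on this core, as on the core of compound 1, the step stays inside the usual scatter. Set beside the earlier ethyl to methyl step, the two cores cannot be told apart on this read-out: the same change on two cores in this assay, a number 1.9 percentage points lower (within the scatter) from compound 2 to compound 1 and a number 6.7 percentage points lower (within the scatter) from compound 3 to compound 4, 4.8 percentage points apart, within the scatter of two such steps. This shows that, in the two pairs available, taking off this terminal methyl gave no step beyond the scatter, whether the methyl sat on a saturated chain carbon bound to an aromatic carbon or on one bound to an oxygen on an aromatic ring; it does not show that the change has no effect at all, since a small real step could lie hidden in the scatter of a reading at one concentration, and two pairs say nothing about any further core.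

The compounds shown leave open how a longer chain such as propoxy, or an amine in place of the ethoxy, would read on the core of compound 3. They also leave open which of the places where the two cores differ accounts for the gap between their values, as no pair shown separates those places.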